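Dropping a methyl from an aryl group on a triazole-thione

The source may hold more compounds than are shown below. What is called first, only, known or untested is meant among the compounds shown, and "the series" means these compounds.

Two compounds share one core and differ only in the aryl group carried on an aromatic nitrogen. Compound 1 `COc1ccc(-n2c(Nc3nc(-c4ccccc4)cs3)n[nH]c2=S)cc1` carries a 4-methoxyphenyl there, and in a functional assay on the whole organism (strain Swiss albino) for inhibition, with Mus musculus as the target, with a stated time of 0.5 h (a lower number here means that less compound is needed, a higher number that more compound is needed for the effect), compound 1 gives 100 mg/kg. Compound 2 `Cc1ccccc1-n1c(Nc2nc(-c3ccccc3)cs2)n[nH]c1=S` carries a 2-methylphenyl instead, and in this assay compound 2 gives 100 mg/kg. The step of no change at the digits printed from compound 1 to compound 2 (within the scatter) shows that swapping 2-methylphenyl for 4-methoxyphenyl made no difference beyond the scatter, so compound 2 stands level with compound 1 on the numbers available.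

Compound 3 `S=c1[nH]nc(Nc2nc(-c3ccccc3)cs2)n1-c1ccccc1` has not yet been tested. It differs from compound 2 by hydrogen in place of methyl on an aromatic carbon; cut one bond further out, the change reads 2-methylphenyl to phenyl. Among the compounds with values here, only one measured step, no change at the digits printed from compound 1 to compound 2 (within the scatter), touches this region of the molecule, and it was flat even though it exchanged a whole substituent and moved it around the ring. Removing a single methyl is a smaller change than that, so the expectation in this assay is a step of no change at the digits printed from compound 2 to compound 3 (within the scatter), that is, none beyond the scatter. Compound 3 is therefore expected to give about 100 mg/kg, within a range from 50 mg/kg to 200 mg/kg.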

Compound 3, minimum effective dose: 300 mg/kg
Compound 3: the middle estimate sits 3.0-fold (0.48 log units) below what was measured; measured number outside the range, above it.
By their numbers in this assay, from the lowest: compounds 1 and 2 (each within the scatter of the next); then compound 3.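

Replacing the methyl with hydrogen gives a 3.0-fold higher number from compound 2 to compound 3 (0.48 log units; beyond the scatter) in this assay, so this aromatic carbon, ortho to a large group, is not indifferent to what it carries, even though the earlier swap of one substituted aryl group for another changed nothing beyond the scatter. Replacing the methoxy with hydrogen gives a 3.0-fold higher number from compound 1 to compound 3 (0.48 log units; beyond the scatter), which places the phenyl of compound 3 apart from both the 4-methoxyphenyl of compound 1 and the 2-methylphenyl of compound 2. Across these three compounds, then, having a substituent on this ring counts for more than which of the two it is, although nothing available here explains the shift.

On these data alone, it remains open whether the level shared by compound 1 and compound 2 would hold for other groups on this ring, such as a chlorine atom, an amine or a longer chain. The roles of the group's identity and its place on the ring also cannot be told apart: compound 1 and compound 2 differ in both at once.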